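The compounds below may be only part of what the source reports. "The series", "measured", "known", "first", "only" and "open" are said of these compounds alone.

In a functional assay on MV4-11 cells (Homo sapiens) for antiproliferative activity, with a stated time of 6 days, tested at 1.56 uM (on this read-out lower numbers stand for a weaker effect and higher numbers for a stronger effect at the one concentration tested), compound 1 `CNC(=O)N1CCCc2ccc(NC(=O)c3ccc(-c4cc[nH]n4)cc3)cc21` gives 92.5%, compound 2 `CNC(=O)N1CCCc2ccc(NC(=O)c3cccc(-c4ccn(C)n4)c3)cc21` gives 70.5%, and compound 3 `CNC(=O)N1CCCc2ccc(NC(=O)c3cccc(-c4cnn(C)c4)c3)cc21` gives 71.2%. Compound 3 thus stands second highest of these three numbers: compound 2 is its nearest neighbour and lies within the scatter, while compound 1 lies well beyond it. Compound 4 `CNC(=O)N1CCCc2ccc(NC(=O)c3cccc(-c4ccn(S(C)(=O)=O)n4)c3)cc21` differs from compound 3 in one place: 1-(methylsulfonyl)-1H-pyrazol-3-yl in place of 1-methyl-1H-pyrazol-4-yl on an aromatic carbon. Among the measured compounds shown here, the only measured step that touches this pair is a number 0.7 percentage points higher from compound 2 to compound 3 (within the scatter), which swapped one pyrazole attachment for another without moving the read-out beyond the scatter. For the measured compounds named here, no measured step involves a methylsulfonyl group on the pyrazole, so the size of this step is unknown, and no change beyond the scatter is the plainest expectation, with a wide range on either side. From compound 3 the expected step is a number 6.2 percentage points lower from compound 3 to compound 4 (within the scatter). Compound 4 is therefore expected to give 65% in this assay, within 35% to 90%.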

Compound 4, a percentage reported as inhibition, at one concentration (the size of the read-out at that concentration, not a potency): 4.03%
Estimate against measurement, compound 4: 61 percentage points above; the whole stated range lies above it.
By their numbers in this assay, from the lowest: compound 4; then compounds 2 and 3 (each within the scatter of the next); then compound 1.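

Changes at this aromatic carbon had so far left the read-out in this assay unmoved, but the substituent on the pyrazole nitrogen proves decisive here. Methylsulfonyl in place of methyl on that nitrogen gives a number 66.5 percentage points lower from compound 2 to compound 4 (beyond the scatter) and so removes nearly all of the effect at this concentration, while the swap from the 1-methyl-1H-pyrazol-4-yl group gives a number 67.2 percentage points lower from compound 3 to compound 4 (beyond the scatter) with much the same outcome. As far as these compounds go, whether the loss belongs to the sulfonyl group itself or extends to other groups larger than methyl stays open; ethyl or acetyl on the same nitrogen would separate the two. No measured evidence accounts for this drop.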